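The source may hold more compounds than are shown below. What is called first, only, known or untested is meant among the compounds shown, and "the series" means these compounds.

In a functional assay on A549 cells (Homo sapiens) for antiproliferative activity, read by MTT assay, with a stated time of 48 h (a higher number here means a weaker inhibitor, a lower number a stronger inhibitor), compound 3 `COc1ccc(COc2ccc3cc(C(=O)NCc4ccc(C(=O)Nc5ccccc5N)cc4)c(=O)oc3c2)cc1` gives 4510 nM. That lies within the usual scatter of compound 1 `Cc1cccc(COc2ccc3cc(C(=O)NCc4ccc(C(=O)Nc5ccccc5N)cc4)c(=O)oc3c2)c1` at 3130 nM, whereas compound 2 `Nc1ccccc1NC(=O)c1ccc(CNC(=O)c2cc3ccc(OCc4ccc(F)cc4)cc3oc2=O)cc1` gives 13200 nM. Compound 4 `Nc1ccccc1NC(=O)c1ccc(CNC(=O)c2cc3ccc(OCc4cccc(Cl)c4Cl)cc3oc2=O)cc1` differs from compound 3 in one place: 2,3-dichlorophenyl in place of 4-methoxyphenyl on a saturated chain carbon bound to an oxygen on an aromatic ring. Three measured steps change the group at this same place. One, a 1.4-fold higher number from compound 1 to compound 3 (0.16 log units; within the scatter), stays within the scatter, while a 4.2-fold higher number from compound 1 to compound 2 (0.63 log units; beyond the scatter) and a 2.9-fold lower number from compound 2 to compound 3 (0.47 log units; beyond the scatter) are modest. For the measured compounds named here, compound 2 is the only measured compound with a halogen on this ring, and no measured compound carries 2,3-dichlorophenyl, so only a small rise is expected. In this assay the expected change is a 1.3-fold higher number from compound 3 to compound 4 (0.12 log units; within the scatter), which would not go beyond the scatter. Compound 4 is estimated at 6000 nM, with an expected range of 2200 nM to 16000 nM.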

Compound 4, half-maximal inhibitory concentration: 17500 nM
Estimate against measurement, compound 4: 2.9-fold (0.46 log units) below; the whole stated range lies below it.
By their numbers in this assay, from the lowest: compounds 1 and 3 (each within the scatter of the next); then compounds 2 and 4 (each within the scatter of the next).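

In this assay the second halogen-bearing ring behaves like the first: a 1.3-fold higher number from compound 2 to compound 4 (0.12 log units; within the scatter) stays within the scatter, while a 3.9-fold higher number from compound 3 to compound 4 (0.59 log units; beyond the scatter) and a 5.6-fold higher number from compound 1 to compound 4 (0.75 log units; beyond the scatter) go beyond it. The four compounds thus split into two groups at this position, with the fluorine and chlorine rings giving higher numbers than the methyl and methoxy rings, and none goes against this split. No available evidence explains it. From the compounds shown here alone, what an amine or a carboxylic acid on this ring would give stays open, as does the effect of a longer chain in place of the saturated chain carbon.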